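Swapping the pyrimidine for a piperidine on the core

A few compounds are considered here, and "the series" means these few. Any claim that something is new, unique, unknown or untested is made for them only; others in the source may bear on it.

Measured compounds:
compound 1, `O=C(O)c1csc(-n2nc(-c3ccc(F)cc3)c3ccccc32)n1`, 4.5 nM
compound 2, `O=C(O)c1csc(-n2nc(C3=CCCCC3)c3ccccc32)n1`, 4 nM
compound 3, `O=C(O)c1csc(-n2nc(-c3cncnc3)c3ccccc32)n1`, > 100 nM

In an assay on isolated protein for antagonist activity at prostaglandin E2 receptor EP1 subtype (Homo sapiens), read by reporter gene assay (a lower number here means a stronger inhibitor, a higher number a weaker inhibitor), compound 1 gives 4.5 nM and compound 2 gives 4 nM; the two sit close together, as the step of a 1.1-fold lower number from compound 1 to compound 2 (0.05 log units; within the scatter) shows. For compound 3 this assay reports only a limit, > 100 nM, and not a number. Compound 3 therefore stands at the weak end of the three, as the steps of an at least 22-fold higher number from compound 1 to compound 3 (1.34 log units; beyond the scatter) and an at least 25-fold higher number from compound 2 to compound 3 (1.39 log units; beyond the scatter) make plain, and the limit of > 100 nM in this assay, at which 1 of the 3 values shown sits, describes where its value sits.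

Compound 4, `O=C(O)c1csc(-n2nc(N3CCCCC3)c3ccccc32)n1`, has not been measured. It differs from compound 3 in one place: piperidin-1-yl in place of pyrimidin-5-yl on an aromatic carbon. The measured steps all concern what sits on that aromatic carbon: an aromatic ring with two nitrogens made compound 3 weak, while a non-aromatic six-membered ring in compound 2 gave a strong inhibitor. The piperidin-1-yl entering in compound 4 is also a non-aromatic six-membered ring, so a lower number than the limit of compound 3 is expected in this assay, a step of an at least 2.5-fold lower number from compound 3 to compound 4 (0.39 log units; beyond the scatter). Compound 4 is thus estimated at 40 nM, within a range from 8 nM to 300 nM, with the exact size uncertain since compound 3 has only a limit.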

Compound 4, half-maximal inhibitory concentration: 16 nM
For compound 4 the middle estimate is 2.5-fold (0.40 log units) above the measured one, within the range that was stated.
By their numbers in this assay, from the lowest: compounds 2 and 1 (each within the scatter of the next); then compound 4. At a limit, above all of these: compound 3.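

Putting piperidin-1-yl on this aromatic carbon in place of pyrimidin-5-yl gives a stronger inhibitor in this assay, an at least 6.2-fold lower number from compound 3 to compound 4 (0.79 log units; beyond the scatter), so a non-aromatic ring with one ring nitrogen is tolerated here better than the aromatic ring with two. Yet the non-aromatic ring alone does not restore the full strength: replacing cyclohex-1-en-1-yl gives a 4.0-fold higher number from compound 2 to compound 4 (0.60 log units; beyond the scatter), and replacing 4-fluorophenyl gives a 3.6-fold higher number from compound 1 to compound 4 (0.55 log units; beyond the scatter), so aromatic against non-aromatic does not decide the outcome, with the aromatic 4-fluorophenyl of compound 1 going against any such rule. Compound 3 has only a limit, so the step away from it gives a minimum size and not an exact one: the limit of > 100 nM in this assay, at which 1 of the 4 values shown sits.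

The compounds shown leave open how a pyridin-3-yl, an aromatic ring with a single ring nitrogen, or a morpholin-4-yl, a non-aromatic ring with an added ring oxygen, would compare with these groups at this carbon. They also cannot say whether the ring nitrogen of compound 4 or some other difference from compound 2 accounts for the gap between those two.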